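Bromo for Fluoro on the Distal Aryl Ring

The source may report more compounds than this note shows. Statements on the series, on what has been measured and on what is new or still open speak of the compounds shown alone.

Compound 2 `O=C(Nc1ccc(Oc2ccnc3[nH]ccc23)c(F)c1)c1cc(-c2ccc(F)cc2)ncn1` was reported in a functional assay on MCF7 cells (Homo sapiens) for cytotoxicity, read by MTT assay, with a stated time of 72 h (on this read-out higher numbers stand for weaker inhibition and lower numbers for stronger inhibition), as "not active" (no number reported), so no number is available for it. Its relative compound 1 `O=C(Nc1ccc(Oc2ccnc3[nH]ccc23)cc1)c1cc(-c2ccc(Br)cc2)ncn1` gives 3840 nM in this assay. Compound 3 `O=C(Nc1ccc(Oc2ccnc3[nH]ccc23)c(F)c1)c1cc(-c2ccc(Br)cc2)ncn1` has not been measured. Compound 3 differs from compound 2 by bromo in place of fluoro on an aromatic carbon, reading one bond further out as 4-fluorophenyl to 4-bromophenyl. No step between measured compounds is shown for this change, so its size in this assay is unknown. For the measured compounds named here, the only anchor is compound 1, which carries the same bromo group and gives a measured number, so the exchange is expected to move compound 3 toward measurable inhibition rather than leave it inactive. Compound 3 is estimated to give 8000 nM in this assay, within a range of 2500 nM to 30000 nM.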

Compound 3, half-maximal inhibitory concentration: 10300 nM
Estimate against measurement, compound 3: 1.3-fold (0.11 log units) below; the range from low to high includes it.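

In this assay compound 3 gives 10300 nM, whereas compound 2 was reported as not active, so 4-bromophenyl yields a measurable value where 4-fluorophenyl yielded none, although the size of that change cannot be read. With the bromo group held constant, fluoro in place of hydrogen on an aromatic carbon gives a 2.7-fold higher number from compound 1 to compound 3 (0.43 log units; beyond the scatter) and thus weaker inhibition, a modest step beyond the scatter. No supporting data are available to explain either observation.

The compounds shown leave open whether chloro, iodo or trifluoromethyl on the same aromatic carbon would also give a measurable value. They also leave open how an amine or a carboxylic acid at that place would compare with bromo.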